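Dropping a Phenyl Group: What Compound 4 May Show

A few compounds are considered here, and "the series" means these few. Any claim that something is new, unique, unknown or untested is made for them only; others in the source may bear on it.

Compound 3 `O=C1C(O)=C(C(c2cccc([N+](=O)[O-])c2)c2c(-c3ccccc3)[nH]c3ccccc23)C(=O)c2ccccc21` gives 13400 nM in a toxicity assay (Homo sapiens) for cytotoxicity, read by MTT assay, with a stated time of 48 h; a lower number here means a stronger inhibitor, a higher number a weaker inhibitor. Compound 2 `COc1ccc(C(C2=C(O)C(=O)c3ccccc3C2=O)c2c[nH]c3ccccc23)cc1Br` gives 25200 nM in this assay, and the two values lie within the usual scatter of each other. Compound 1 `COc1ccccc1C(C1=C(O)C(=O)c2ccccc2C1=O)c1c[nH]c2ccccc12` reaches only the limit > 200000 nM in this assay (the limit of > 200000 nM in this assay, at which 1 of the 3 values shown sits). Within the data shown here, the one measured step, an at least 7.9-fold lower number from compound 1 to compound 2 (0.89 log units; beyond the scatter), concerns the aryl group on the saturated chain carbon. Compound 4 `O=C1C(O)=C(C(c2cccc([N+](=O)[O-])c2)c2c[nH]c3ccccc23)C(=O)c2ccccc21` differs from compound 3 by hydrogen in place of phenyl on an aromatic carbon. Among the measured compounds shown here, no measured step touches this position, so the only guide is the range of numbers seen so far. For compound 4 the expected value in this assay is 20000 nM, between 6000 nM and 80000 nM. This amounts to an expected step of a 1.5-fold higher number from compound 3 to compound 4 (0.17 log units; within the scatter), not clearly beyond the scatter.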

Compound 4, half-maximal inhibitory concentration: 91200 nM
Compound 4: middle estimate off by 4.6-fold (0.66 log units), on the low side; measured number above the stated range.
By their numbers in this assay, from the lowest: compounds 3 and 2 (each within the scatter of the next); then compound 4. At a limit, above all of these: compound 1.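

Among these compounds, removing the phenyl group from the aromatic carbon next to the ring nitrogen gives a 6.8-fold higher number from compound 3 to compound 4 (0.83 log units; beyond the scatter) in the first measured step at this position. With hydrogen on that carbon, the aryl group on the saturated chain carbon also counts, as 3-nitrophenyl in place of 3-bromo-4-methoxyphenyl gives a 3.6-fold higher number from compound 2 to compound 4 (0.56 log units; beyond the scatter) for this pair. Compound 1 stands at a limit rather than a number, so an at least 2.1-fold lower number from compound 1 to compound 4 (0.34 log units; beyond the scatter) is only a bound: the limit of > 200000 nM in this assay, at which 1 of the 4 values shown sits.

Going by these compounds, whether methyl or an amine on that aromatic carbon would give a number nearer compound 3 or compound 4 remains open. So does whether the phenyl step would repeat with 3-bromo-4-methoxyphenyl on the chain carbon.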